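The source may report more compounds than this note shows. Statements on the series, on what has been measured and on what is new or still open speak of the compounds shown alone.

Measured compounds in the series:
- compound 1 `COc1cccc(CNC(=O)c2nc(Br)c3cccnc3c2N[C@H]2CC[C@H](N)CC2)c1`: "not determined" (no result reported) in a functional assay on MCF7 cells (Homo sapiens) for cytotoxicity, read by MTT assay, with a stated time of 72 h; a higher number here means a weaker inhibitor, a lower number a stronger inhibitor
- compound 2 `N[C@H]1CC[C@H](Nc2c(C(=O)NCc3ccc(Cl)cc3)nc(Br)c3cccnc23)CC1`: "not determined" (no result reported) in this assay
- compound 3 `N[C@H]1CC[C@H](Nc2c(C(=O)NCc3ccc(Oc4ccccc4)cc3)nc(Br)c3cccnc23)CC1`: 7900 nM

Compound 2 stands without a single number in this assay, and compound 1 likewise carries no result there, so the only anchor for the shared core is compound 3, whose half-maximal inhibitory concentration in this assay is 7900 nM. For the measured compounds named here, no step between two measured compounds can be computed from these entries.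

Compound 4 `N[C@H]1CC[C@H](Nc2c(C(=O)NCc3ccccn3)nc(Br)c3cccnc23)CC1` is the next analogue. It differs from compound 2 in one place (pyridin-2-yl in place of 4-chlorophenyl on a saturated chain carbon bound to an amide-type nitrogen). Nothing measured on either side of this change is available, so the size of the step in this assay cannot be drawn from the data; the expectation is a step of no more than modest size, with a direction toward a weaker inhibitor not excluded, given that compound 3 sits at 7900 nM.

For compound 4 the half-maximal inhibitory concentration in this assay is estimated at 12000 nM, with a range of 3000 nM to 50000 nM.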

Compound 4, half-maximal inhibitory concentration: 15000 nM
Estimate against measurement, compound 4: 1.3-fold (0.10 log units) below, and the stated range covers the measured number.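

For the compounds shown here, compound 2 holds no single number in this assay and so no step to compound 4 can be read. The compounds shown leave open how pyridin-2-yl and 4-chlorophenyl compare on the shared core. No measured evidence bears on this result.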